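The compounds below may be only part of what the source reports. "The series", "measured", "known", "first", "only" and "open" are said of these compounds alone.

Compound 1 `Cc1nn([C@H](C)c2ccc(Cl)cc2Cl)c2nc(N3CC[C@H](N4CCC4)[C@H](C)C3)cnc12` gives 58 nM in a functional assay on cells for antagonist activity at C-C chemokine receptor type 4 (Homo sapiens), read by fluorescence and calcium flux, with stated times of 2.5 s and 45 s (on this read-out lower numbers stand for stronger inhibition and higher numbers for weaker inhibition), the lowest of the three numbers recorded. Within the data shown here, compound 2 `Cc1nn(C(C)c2ccc(Cl)cc2Cl)c2nc(N3CCC(N4CCCCC4)C(C)C3)cnc12` gives 126 nM, and compound 3 `CC1CN(c2cnc3cnn(C(C)c4ccc(Cl)cc4Cl)c3n2)CCC1N1CCCCC1` gives 238 nM; the only single-change step among them, a 1.9-fold higher number from compound 2 to compound 3 (0.28 log units; within the scatter), concerns the methyl on the aromatic carbon and lies within the scatter. Compound 4 `Cc1nn([C@H](C)c2ccc(Cl)cc2Cl)c2nc(N3CC[C@H](N4CCCCCC4)[C@H](C)C3)cnc12` differs from compound 1 by azepan-1-yl in place of azetidin-1-yl on a saturated ring carbon. Among the measured compounds shown here, no measured step addresses this change directly; the values of compound 1 and compound 2 show that a larger saturated ring on that carbon goes with a higher number, and compound 4 carries the largest ring of the set. Compound 4 is therefore expected near 150 nM, between 60 nM and 400 nM. The expected step is a 2.6-fold higher number from compound 1 to compound 4 (0.41 log units; beyond the scatter).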

Compound 4, half-maximal inhibitory concentration: 23 nM
For compound 4 the middle estimate is 6.5-fold (0.81 log units) above the measured one; the whole stated range lies above it.
By their numbers in this assay, from the lowest: compound 4; then compound 1; then compounds 2 and 3 (each within the scatter of the next).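

Among the compounds shown, this is the only single-change step at the saturated ring carbon: azepan-1-yl in place of azetidin-1-yl gives a 2.5-fold lower number from compound 1 to compound 4 (0.40 log units; beyond the scatter) in this assay, a modest change. With the rest of compound 1 held constant, the seven-membered ring therefore goes with the lower number, so this carbon accepts the larger ring. Nothing available explains the step. On these data alone, with only the four- and seven-membered rings compared directly, it remains open how pyrrolidin-1-yl or morpholin-4-yl would read at this carbon. An open-chain amine such as dimethylamino there is also untested by these compounds.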